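This account rests on a few compounds, and the source may have more. Where it says the series, first, only, none or still open, it means among the compounds named here.

Measured compounds:
compound 1 `COc1ccc(NC(=O)Nc2nc(-c3cc4cc([N+](=O)[O-])ccc4o3)cs2)cc1` — 121000 nM
compound 2 `O=C(Nc1cccc([N+](=O)[O-])c1)Nc1nc(-c2cc3cc(Br)ccc3o2)cs1` — 159000 nM
compound 3 `O=C(Nc1ccc([N+](=O)[O-])cc1)Nc1nc(-c2cc3cc(Br)ccc3o2)cs1` — reported only as a limit of the assay, > 200000 nM

In a physicochemical assay, with a stated time of 6 min (a lower number here means a stronger inhibitor, a higher number a weaker inhibitor), compound 1 stands at the lowest of the two numbers; compound 2 stands within the scatter of it, so no order can be read between them. Compound 3 sits at the limit of > 200000 nM in this assay, at which 1 of the 3 values shown sits, which is a limit and not a number. Among the compounds with values here, the single measured step, an at least 1.2-fold higher number from compound 2 to compound 3 (0.09 log units; that floor lies within the scatter), concerns the nitrophenyl attached to the urea and only reaches a floor that lies within the scatter.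

Compound 4 `COc1ccc(NC(=O)Nc2nc(-c3cc4ccccc4o3)cs2)cc1` is the unmeasured one. Relative to compound 1 the change is hydrogen in place of nitro on an aromatic carbon. Within the data shown here, no measured step bears on this change: compounds 2 and 3 carry bromine rather than nitro on the fused ring system, but each also differs from compound 1 at the urea end, so no single step from compound 1 to either of them is defined. What the numbers do show is that every value in this set is weak, with compound 1 and compound 2 within scatter of each other despite the different group on the fused ring. The step of a 1.3-fold higher number from compound 1 to compound 4 (0.12 log units; within the scatter) is therefore expected to stay within or near the scatter, with a tilt toward a higher number. Compound 4 is estimated at 160000 nM, within a range from 60000 nM to 400000 nM.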

Compound 4, half-maximal inhibitory concentration: 17400 nM
Compound 4: middle estimate off by 9.2-fold (0.96 log units), on the high side; measured number below the stated range.
By their numbers in this assay, from the lowest: compound 4; then compounds 1 and 2 (each within the scatter of the next). At a limit, above all of these: compound 3.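

In this assay, within the data shown here, the change from nitro to hydrogen on the six-membered aromatic ring of the fused system gives a 7.0-fold lower number from compound 1 to compound 4 (0.84 log units; beyond the scatter), the only step in this set that is printed as beyond the scatter. This position therefore responds to what it carries, which compounds 1, 2 and 3 could not show, as compounds 2 and 3 differ from compound 1 at both the urea end and the fused ring; the nitro is also not needed for inhibition, since compound 4, with hydrogen in its place, gives 17400 nM. The measurements shown hold nothing that accounts for the size or direction of this step.

From the compounds shown here alone, with only nitro and hydrogen compared directly on an otherwise identical 4-methoxyphenyl urea, it remains open how other groups at this position, such as fluorine, an amine or a nitrile, would compare with hydrogen. The contribution of bromine at this position also remains unresolved, as both compounds that carry it have a nitrophenyl rather than the methoxyphenyl at the urea end.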